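This account rests on a few compounds, and the source may have more. Where it says the series, first, only, none or still open, it means among the compounds named here.

Compound 3 `CN1CCN(CCNCc2cn(-c3ccc(F)cc3F)nc2-c2ccccc2)CC1` shows in an ADME assay on Huh-7 cells (Homo sapiens) for cytotoxicity (on this read-out lower numbers stand for higher toxicity in this test and higher numbers for lower toxicity in this test), a value of > 20000 nM, which is a limit of the test rather than a measured number. Its two neighbours give numbers: compound 1 `CN1CCN(CCNCc2cn(-c3ccc(F)cc3F)nc2-c2ccc(OC(F)(F)F)cc2)CC1` gives 18000 nM and compound 2 `CN1CCN(CCNCc2cn(-c3ccc(F)cc3F)nc2-c2ccc(C(F)(F)F)cc2)CC1` gives 20000 nM. The steps among these three are a 1.1-fold higher number from compound 1 to compound 2 (0.05 log units; within the scatter), an at least 1.1-fold higher number from compound 1 to compound 3 (0.04 log units; that floor lies within the scatter) and a number no lower from compound 2 to compound 3 (the limit leaves the size open), all three at or near the limit (the limit of > 20000 nM in this assay, at which 1 of the 3 values shown sits). Compound 4 `CN1CCN(CCNCc2cn(-c3ccc(F)cc3F)nc2C(C)(C)C)CC1` differs from compound 3 by tert-butyl in place of phenyl on an aromatic carbon. Among the measured compounds shown here, none of the measured steps touches that position, so they give no direction; all stay within the scatter, and on that basis no step beyond the scatter is expected. The estimate for compound 4 is 20000 nM (range 9000 nM to 40000 nM), a step of a number no higher from compound 3 to compound 4 (the limit leaves the size open).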

Compound 4, half-maximal cytotoxic concentration: > 20000 nM
Compound 4: no number, only a limit (the forecaster's own chance of this, stated with the estimate: 55%); the middle value lies on the limit itself.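

The earlier compounds shown here changed only what sits on the phenyl ring, whereas here the whole ring gives way to tert-butyl, and in this assay compound 4 gives > 20000 nM, which is a limit and not a number. Among the compounds shown here, the one step with a readable floor is an at least 1.1-fold higher number from compound 1 to compound 4 (0.04 log units; that floor lies within the scatter). The data also print a number no lower from compound 2 to compound 4 (the limit leaves the size open). The step to compound 4 from compound 3 cannot be read, so removing the ring shows no sign of a lower number here, though the test cannot show more: the limit of > 20000 nM in this assay, at which 2 of the 4 values shown sit.

Still open, as far as these compounds go, is how far compound 3 and compound 4 lie past this limit. Also open, from the compounds shown here alone, is whether an amine or a carboxylic acid at this position would give a measurable number.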